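A few compounds are considered here, and "the series" means these few. Any claim that something is new, unique, unknown or untested is made for them only; others in the source may bear on it.

Measured compounds in a functional assay on HEK293 cells for agonist activity at D(4) dopamine receptor (Homo sapiens), read by FLIPR; on this read-out higher numbers stand for larger maximal responses and lower numbers for smaller maximal responses:
compound 1 `O=C(CN1CCC(c2cccc[n+]2[O-])CC1)Nc1cccc(F)c1` gives 70%
compound 2 `Cc1cccc(NC(=O)CN2CCC(c3ccc(O)cc3)CC2)c1` gives 60%
compound 3 `Cc1ccc(Cl)c(NC(=O)CN2CCC(c3cccc[n+]3[O-])CC2)c1Cl` gives 62%

Among these three, compound 1 holds the highest number, yet neither gap is telling: compound 3 sits somewhat lower and compound 2 a little lower still, and both distances fall within the scatter of repeated runs of this assay. So compound 1 stands at the top of a tight group rather than apart from it.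

Compound 4 `O=C(CN1CCC(c2cccc[n+]2[O-])CC1)Nc1cccc(Cl)c1` has not yet been measured in this assay. It differs from compound 1 in a single place: chloro in place of fluoro on an aromatic carbon. Among the compounds with values here, nothing else about the shared core changes, and no measured pair in this set shows a step of this kind, so there is no direct precedent to lean on. Given how narrowly the three measured compounds cluster, the reasonable expectation is a small step, none beyond the scatter, in either direction. The expected step of a number 2 percentage points lower from compound 1 to compound 4 (within the scatter) is therefore estimated to be modest. Compound 4 is expected to reach about 68%, with a likely range from 55% to 80%.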

Compound 4, largest response reached (reported as efficacy), in percent of the reference or control that the assay uses: 76%
The estimate for compound 4 lay 8 percentage points below the measured number; measured number inside the range.
By their numbers in this assay, from the lowest: compounds 2, 3, 1 and 4 (each within the scatter of the next, the first and the last beyond it).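

In this assay, within the data shown here, the exchange of fluoro for chloro on an aromatic carbon, meta to a large group, gives the first step that can be read at this position: a number 6 percentage points higher from compound 1 to compound 4 (within the scatter) on the shared core. The position therefore accepts this one-atom exchange without a difference in maximal response that can be told apart from the scatter, so the 3-fluorophenyl and 3-chlorophenyl compounds read alike here. Nothing at hand explains this result.

The compounds shown leave open whether bromo, nitrile or methoxy on that same aromatic carbon would also stay within the scatter of compound 1. They also leave open whether an amine or a carboxylic acid there would move the maximal response beyond it.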